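Sulfonamide variation on the benzoxazole aniline series

A few compounds are considered here, and "the series" means these few. Any claim that something is new, unique, unknown or untested is made for them only; others in the source may bear on it.

Measured so far in an assay on cells for inhibition of HSP60/HSP10 (Homo sapiens), with a stated time of 60 min; a lower number here means a stronger inhibitor, a higher number a weaker inhibitor:
compound 1 `O=S(=O)(Nc1ccc(-c2nc3ccccc3o2)cc1)c1cccc(F)c1`: 71000 nM
compound 2 `O=S(=O)(Nc1ccc(-c2nc3cc(NS(=O)(=O)c4ccccc4O)ccc3o2)cc1)c1ccccc1O`: 18000 nM
compound 3 `Cc1ccc(S(=O)(=O)Nc2ccc3oc(-c4ccccc4)nc3c2)cc1`: > 100000 nM

Compound 1 stands as the higher of the two numbers in this assay; compound 2, the nearest, gives 18000 nM, and that gap lies beyond the usual scatter. Compound 3 sits at a limit of this assay, so no number is known for it. One of the three values thus rests at the limit (the limit of > 100000 nM in this assay, at which 1 of the 3 values shown sits).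

Compound 4 `O=S(=O)(Nc1ccc(-c2nc3ccccc3o2)cc1)c1ccc(Cl)s1` is the next compound to be measured. It differs from compound 1 in one place: 5-chlorothiophen-2-yl in place of 3-fluorophenyl on a sulfonyl sulfur. Among the measured compounds shown here, no step between two measured compounds isolates a change of this kind, so there is nothing among the measured compounds to set its direction or size. The expectation is a step of a 1.2-fold lower number from compound 1 to compound 4 (0.07 log units; within the scatter), no larger than the usual scatter. Compound 4 is therefore expected to give about 60000 nM, within a range from 20000 nM to 150000 nM, with a real chance that this assay reports only a limit.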

Compound 4, half-maximal inhibitory concentration: 31000 nM
Compound 4: middle estimate off by 1.9-fold (0.29 log units), on the high side; the range from low to high includes it.
By their numbers in this assay, from the lowest: compounds 2 and 4 (each within the scatter of the next); then compound 1. At a limit, above all of these: compound 3.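

On the sulfonyl sulfur, the attached ring does affect the result in this assay: 5-chlorothiophen-2-yl in place of 3-fluorophenyl gives a 2.3-fold lower number from compound 1 to compound 4 (0.36 log units; beyond the scatter). Among the compounds shown here, this is the only single-place step so far, and it shows that this position alone can move the number beyond the scatter, though compound 4 at 31000 nM remains a weak inhibitor. The 3-fluorophenyl ring is therefore not required here, but the data give no cause for the step.

As far as these compounds go, the step changes the ring and the chlorine together, so their separate shares remain open. Also open, from the compounds shown here alone, are the results for a plain thiophen-2-yl on the sulfonyl sulfur and for a thiophene carrying a carboxylic acid or an amine in place of the chlorine.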